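The source may report more compounds than this note shows. Statements on the series, on what has been measured and on what is new or still open speak of the compounds shown alone.

Measured so far in a physicochemical assay for lipophilicity, read by HPLC, at pH 7.5; a higher number here means a more lipophilic compound, a lower number a more polar compound:
compound 1 `CCOc1ccccc1-c1ccc(-c2nc3cnccc3c(N[C@H](CC)C(N)=O)c2C#N)cc1` gives 3
compound 2 `CC[C@@H](Nc1c(C#N)c(-c2ccc(-c3cccc(OC)c3)cc2)nc2cnccc12)C(N)=O` gives 2.7
compound 3 `CC[C@@H](Nc1c(C#N)c(-c2ccc(-c3ccccc3N(C)C)cc2)nc2cnccc12)C(N)=O` gives 3.2

Compound 1 stands second highest of the three numbers; its nearest neighbour is compound 3, a number 0.20 log units higher from compound 1 to compound 3 (within the scatter), and the furthest is compound 2, a number 0.30 log units lower from compound 1 to compound 2 (within the scatter). Within the data shown here, the one step beyond the scatter is a number 0.50 log units higher from compound 2 to compound 3 (beyond the scatter). Compound 4 `CCOc1ccccc1-c1ccc(-c2nc3cnccc3c(NC(CC)CNS(=O)(=O)C3CC3)c2C#N)cc1` differs from compound 1 by a group of 11 heavy atoms (7 carbon, 1 nitrogen, 2 oxygen, 1 sulfur; one three-membered non-aromatic ring of carbon only) in place of a group of 6 heavy atoms (4 carbon, 1 nitrogen, 1 oxygen; no ring), on a nitrogen on an aromatic ring. Among the measured compounds shown here, all three measured steps concern the substituted phenyl group; none touches the nitrogen on an aromatic ring where compound 4 is altered, so no measured step bears directly on this change and the expectation rests on the change itself. An increase in this assay is expected, estimated as a number 0.70 log units higher from compound 1 to compound 4 (beyond the scatter). For compound 4 the expected value is 3.7, in the range 3.1 to 4.3.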

Compound 4, distribution coefficient: 3.6
Beside the measured number, compound 4's estimate is 0.10 log units above it; the range from low to high includes it.
By their numbers in this assay, from the lowest: compounds 2, 1 and 3 (each within the scatter of the next, the first and the last beyond it); then compound 4.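

At the nitrogen on an aromatic ring, replacing 1-carbamoylpropyl with the larger group carrying a three-membered ring of carbon only gives a clear change in this assay, a number 0.60 log units higher from compound 1 to compound 4 (beyond the scatter), beyond the scatter. This is the first step shown at this place, as all earlier steps concern the substituted phenyl group. The change alters several features at once, so the step belongs to the whole group and not to any one part of it.

Going by these compounds, how a carboxylic acid or an amine at this place would read remains open. On these data alone, what underlies the step also remains open, with no measurement at hand bearing on it.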